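Swapping the aryl group on the exocyclic double bond

The source may hold more compounds than are shown below. What is called first, only, known or untested is meant among the compounds shown, and "the series" means these compounds.

Compound 1, `Cc1cccc(/C=C2/SC(N3CCC[C@H]3C(=O)Nc3ccc4ncnc(Nc5cccc(Cl)c5)c4c3)=NC2=O)n1`, gives 4500 nM in a functional assay on HepG2 cells (Homo sapiens) for antiproliferative activity, read by MTT assay; a lower number here means a stronger inhibitor, a higher number a weaker inhibitor.
Compound 2, `O=C1N=C(N2CCC[C@H]2C(=O)Nc2ccc3ncnc(Nc4cccc(Cl)c4)c3c2)S/C1=C/c1cccnc1`, gives 8500 nM in this assay.
Compound 3, `O=C1N=C(N2CCC[C@H]2C(=O)Nc2ccc3ncnc(Nc4cccc(Cl)c4)c3c2)S/C1=C/c1cccnc1Cl`, gives 6400 nM in this assay.

All three compounds share the same core and differ only in the aromatic ring on a double-bonded chain carbon bound to a double-bonded ring carbon. Compound 3 sits between the other two: its nearest neighbour is compound 2, with a 1.3-fold lower number from compound 2 to compound 3 (0.12 log units; within the scatter), and the wider gap is to compound 1, with a 1.4-fold higher number from compound 1 to compound 3 (0.15 log units; within the scatter). Among the measured compounds shown here, both of these are within the scatter, as is a 1.9-fold higher number from compound 1 to compound 2 (0.28 log units; within the scatter), so on the numbers so far no ring at this position stands apart from the others.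

Compound 4, `O=C1N=C(N2CCC[C@H]2C(=O)Nc2ccc3ncnc(Nc4cccc(Cl)c4)c3c2)S/C1=C/c1ccccc1F`, is not yet measured. It changes (2-fluorophenyl in place of 2-chloropyridin-3-yl on a double-bonded chain carbon bound to a double-bonded ring carbon). The three measured steps all alter the same position, two of them by exchanging the whole ring and one by adding a chloro, and none moved this assay beyond the scatter. The same is therefore expected here: a 1.1-fold lower number from compound 3 to compound 4 (0.03 log units; within the scatter) is estimated to stay within the scatter, with no clear direction. Compound 4 is expected to give about 6000 nM, in a range from 2500 nM to 15000 nM.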

Compound 4, half-maximal inhibitory concentration: 18200 nM
Beside the measured number, compound 4's estimate is 3.0-fold (0.48 log units) below it; measured number outside the range, above it.
By their numbers in this assay, from the lowest: compounds 1, 3 and 2 (each within the scatter of the next); then compound 4.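

This position is more sensitive in this assay than the three pyridine-bearing compounds suggested, as their ring changes all stayed within the scatter. Among the compounds shown here, the 2-fluorophenyl ring is the first group here to move the number beyond the scatter, and it does so against all three of the others (a 2.8-fold higher number from compound 3 to compound 4 (0.45 log units; beyond the scatter); a 2.1-fold higher number from compound 2 to compound 4 (0.33 log units; beyond the scatter); a 4.0-fold higher number from compound 1 to compound 4 (0.61 log units; beyond the scatter)), which makes compound 4 the weakest inhibitor of the four. Among these compounds, the only ring made of carbon alone is also the only one that stands apart, and no compound goes against this, although it rests on compound 4 alone and the swap from compound 3 also exchanges chloro for fluoro.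

The compounds shown cannot separate the loss of the ring nitrogen from the change of substituent, and a plain phenyl, a 2-chlorophenyl or a 2-fluoropyridin-3-yl at this position would be needed to tell the two apart. Nothing available explains why this ring gives the higher number.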